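Adding a Methoxy Group to a Potent Modulator

The compounds below may be only part of what the source reports. "The series", "measured", "known", "first", "only" and "open" are said of these compounds alone.

Compound 1 `COc1cccc(-c2noc(C3CC(=O)N(c4ccc(Cl)cc4)C3)n2)c1`: 4800 nM
Compound 2 `O=C1CC(c2nc(-c3ccccc3)no2)CN1c1ccc(F)cc1`: 58 nM

In an in vitro functional assay on HEK293-A cells for positive allosteric modulation of metabotropic glutamate receptor 5 (Homo sapiens), read by FLIPR and calcium flux (on this read-out lower numbers stand for an effect already at smaller amounts and higher numbers for an effect only at larger amounts of compound), compound 1 gives 4800 nM, while compound 2 gives 58 nM. Compound 2 has the lowest number of the two; the gap to compound 1 is beyond the scatter. Compound 3 `COc1cccc(-c2noc(C3CC(=O)N(c4ccc(F)cc4)C3)n2)c1` has not been measured. It differs from compound 2 by methoxy in place of hydrogen on an aromatic carbon. Going by the values given here, compound 1 carries the same methoxy group and shows a much higher number, but it also differs from compound 2 in another place, so no single step is known. The step of a 10-fold higher number from compound 2 to compound 3 (1.01 log units; beyond the scatter) is expected to raise the number clearly. Compound 3 is estimated at 600 nM, between 150 nM and 3000 nM.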

Compound 3, half-maximal effective concentration: 1100 nM
The estimate for compound 3 lay 1.8-fold (0.26 log units) below the measured number; the measured number falls inside the stated range.
By their numbers in this assay, from the lowest: compound 2; then compound 3; then compound 1.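

Methoxy in place of hydrogen, the change from phenyl to 3-methoxyphenyl, gives a 19-fold higher number from compound 2 to compound 3 (1.28 log units; beyond the scatter) with nothing else altered, so this single group on the ring raises the number clearly. Fluoro in place of chloro, with the methoxy kept, gives a 4.4-fold lower number from compound 1 to compound 3 (0.64 log units; beyond the scatter) as a separate step, so both changes contribute to the gap between compound 1 and compound 2. Nothing measured here explains either step.

Going by these compounds, whether a methyl, a hydroxyl or an amine at this ring carbon would raise the number as much remains open. So does the effect of methoxy on other carbons of the ring.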